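This account rests on a few compounds, and the source may have more. Where it says the series, first, only, none or still open, it means among the compounds named here.

The measured compounds in a functional assay on A549 cells (Homo sapiens) for cytotoxicity, read by MTT assay, with a stated time of 72 h; on this read-out higher numbers stand for weaker inhibition and lower numbers for stronger inhibition:
compound 1 `Cc1c(C(=O)Nc2ccc(Oc3ccnc4[nH]ccc34)cc2)nnn1-c1ccccc1F` gives 320 nM;
compound 2 `Cc1c(C(=O)Nc2ccc(Oc3ccnc4[nH]ccc34)cc2)nnn1-c1ccc(F)cc1` gives 220 nM;
compound 3 `Cc1c(C(=O)Nc2ccc(Oc3ccnc4[nH]ccc34)cc2)nnn1-c1ccc(F)c(F)c1` gives 2260 nM.

Compound 1 stands second highest of the three numbers, nearest to compound 2 (a 1.5-fold lower number from compound 1 to compound 2 (0.16 log units; within the scatter)) and furthest from compound 3 (a 7.1-fold higher number from compound 1 to compound 3 (0.85 log units; beyond the scatter)). Compound 4 `O=C(Nc1ccc(Oc2ccnc3[nH]ccc23)cc1)c1nnn(-c2ccccc2F)c1C(F)(F)F` differs from it in one place: trifluoromethyl in place of methyl on an aromatic carbon. Going by the values given here, none of the measured steps changes the methyl group; all three alter the fluorophenyl group on the ring nitrogen, and there the steps ran from within the scatter (a 1.5-fold lower number from compound 1 to compound 2 (0.16 log units; within the scatter)) to large (a 10-fold higher number from compound 2 to compound 3 (1.01 log units; beyond the scatter)). Among the compounds with values here, with no direct precedent, the step expected for compound 4 is a 1.4-fold higher number from compound 1 to compound 4 (0.15 log units; within the scatter). The estimate for compound 4 in this assay is 450 nM, between 120 nM and 1800 nM.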

Compound 4, half-maximal inhibitory concentration: 210 nM
Compound 4: the middle estimate sits 2.1-fold (0.33 log units) above what was measured; measured number inside the range.
By their numbers in this assay, from the lowest: compounds 4, 2 and 1 (each within the scatter of the next); then compound 3.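

In this assay, the aromatic carbon that bears a 2-fluorophenyl group next to it takes trifluoromethyl in place of methyl with a 1.5-fold lower number from compound 1 to compound 4 (0.18 log units; within the scatter), so going from 1 heavy atom to 4 heavy atoms here does not move the number beyond the scatter. Going by these compounds alone, this is the first reading at this position, and it contrasts with the change on the fluorophenyl group, where fluoro in place of hydrogen gave a 10-fold higher number from compound 2 to compound 3 (1.01 log units; beyond the scatter). Nothing measured here accounts for this difference. As far as these compounds go, whether this carbon also accepts an amine, a carboxylic acid or a longer chain remains open. So does whether trifluoromethyl behaves the same way alongside the 4-fluorophenyl group of compound 2 or the 3,4-difluorophenyl group of compound 3.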